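The source may report more compounds than this note shows. Statements on the series, on what has been measured and on what is new or still open speak of the compounds shown alone.

Series notes. Four analogues share one core and differ at the sulfonyl group and at the amine substituent. Among the compounds with values here, compound 1 `Cn1c(=O)c(S(=O)(=O)c2ccc(F)cc2F)cc2cnc(Nc3ccc4cc[nH]c4c3)nc21`, compound 2 `Cn1c(=O)c(S(=O)(=O)Cc2ccc(F)cc2)cc2cnc(Nc3ccc4[nH]ccc4c3)nc21`, compound 3 `Cn1c(=O)c(S(=O)(=O)c2ccc(Cl)cc2)cc2cnc(Nc3cnc4ccccc4c3)nc21` and compound 4 `Cn1c(=O)c(S(=O)(=O)Nc2ccc(F)cc2F)cc2cnc(Nc3ccc4[nH]ccc4c3)nc21` are the set; compound 4 has no measurement yet.

In a functional assay on DU-145 cells (Homo sapiens) for inhibition, read by trypan blue exclusion, with a stated time of 72 h (a lower number here means a stronger inhibitor, a higher number a weaker inhibitor), compound 1 gives 5000 nM. In this assay compound 2 gives 30000 nM and compound 3 gives 15000 nM. Compound 2 and compound 3 sit within the scatter of each other, so no order between them is claimed. Compound 1 lies beyond the scatter from compound 2, with the lower number, and no single-point comparison exists between any pair of these three.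

Compound 4 differs from compound 2 in one place: (2,4-difluorophenyl)amino in place of 4-fluorobenzyl on a sulfonyl sulfur. Within the data shown here, no measured pair isolates this kind of change, so the direction rests on no data. Compound 1, which also carries a 2,4-difluorophenyl on the sulfonyl sulfur, gives 5000 nM in this assay, but its amine substituent differs as well, so that comparison is not clean. The expectation is a step from compound 2 to compound 4 of a 2.0-fold lower number from compound 2 to compound 4 (0.30 log units; within the scatter), not clearly beyond the scatter.

Compound 4 is estimated at 15000 nM in this assay, with a range from 4000 nM to 60000 nM.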

Compound 4, half-maximal inhibitory concentration: 5000 nM
Beside the measured number, compound 4's estimate is 3.0-fold (0.48 log units) above it; low and high end bracket the measured number.
By their numbers in this assay, from the lowest: compounds 1 and 4 (each within the scatter of the next); then compounds 3 and 2 (each within the scatter of the next).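

Within the data shown here, the only one-place comparison so far comes from (2,4-difluorophenyl)amino in place of 4-fluorobenzyl on a sulfonyl sulfur, which in this assay gives a 6.0-fold lower number from compound 2 to compound 4 (0.78 log units; beyond the scatter). With the shared core and the amine substituent unchanged, this shows that the group on the sulfonyl sulfur can by itself move the number by more than the scatter. The data shown offer no explanation for this step.

The change alters the atom attached to the sulfonyl sulfur, the number of fluorine atoms and the hydrogen-bond donor count all at once, so the compounds shown do not separate these contributions; a phenylamino, a 4-fluorophenylamino or a 2,4-difluorobenzyl group at this place would be needed to tell them apart. Among these compounds, it also remains open whether the same change gives a step of similar size when the amine substituent is the one carried by compound 1 or compound 3.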